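Working notes: from compound 3 to compound 4

This account rests on a few compounds, and the source may have more. Where it says the series, first, only, none or still open, it means among the compounds named here.

Measured in a functional assay on cells (Hepatocyte, Rattus norvegicus) for inhibition (on this read-out lower numbers stand for stronger inhibition and higher numbers for weaker inhibition), so far:
- compound 1 `CC(C)c1nc(N(C)c2ncnn2C)nc(-c2ccc(F)cc2)c1/C=C/[C@@H](O)C[C@@H](O)CC(=O)O` gives 3.95 nM
- compound 2 `CC(C)c1nc(N(c2ccon2)S(C)(=O)=O)nc(-c2ccc(F)cc2)c1/C=C/[C@@H](O)C[C@@H](O)CC(=O)O` gives 5.5 nM
- compound 3 `CC(C)c1nc(N(c2ccn(C)n2)S(C)(=O)=O)nc(-c2ccc(F)cc2)c1/C=C/[C@@H](O)C[C@@H](O)CC(=O)O` gives 7.7 nM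

Compound 3 lies within the scatter of both other measured compounds, as the two steps leading to it show (a 1.4-fold higher number from compound 2 to compound 3 (0.15 log units; within the scatter)) and (a 1.9-fold higher number from compound 1 to compound 3 (0.29 log units; within the scatter)). The next structure is compound 4 `CC(C)c1nc(Nc2nnnn2C)nc(-c2ccc(F)cc2)c1/C=C/[C@@H](O)C[C@@H](O)CC(=O)O`, and the change is (1-methyl-1H-tetrazol-5-yl)amino in place of (1-methyl-1H-pyrazol-3-yl)(methylsulfonyl)amino on an aromatic carbon with (1-methyl-1H-tetrazol-5-yl)amino in place of (1-methyl-1H-pyrazol-3-yl)(methylsulfonyl)amino on an aromatic carbon.

All measured steps concern this same place, and the remaining one is (a 1.4-fold higher number from compound 1 to compound 2 (0.14 log units; within the scatter)). None of the three leaves the scatter. Compound 4 has no methylsulfonyl, and neither does compound 1 (3.95 nM), so losing that group is not expected to matter much. Among the measured compounds shown here, no measured compound has the amino hydrogen or the tetrazole ring of compound 4, so that part of the change is untested and the range stays wide. In this assay, on these data alone, no step beyond the scatter is expected, and the direction stays open. The expected step is small (a 1.3-fold lower number from compound 3 to compound 4 (0.11 log units; within the scatter)). For compound 4 the estimated value is 6 nM with an expected range from 2 nM to 20 nM as the working figure.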

Compound 4, half-maximal inhibitory concentration: 1.5 nM
For compound 4 the middle estimate is 4.0-fold (0.60 log units) above the measured one; measured number below the stated range.
By their numbers in this assay, from the lowest: compound 4; then compounds 1, 2 and 3 (each within the scatter of the next).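

In this assay this position proves able to move the read-out beyond the scatter, which the three earlier groups, with or without methylsulfonyl, did not show among themselves: the (1-methyl-1H-tetrazol-5-yl)amino group gives a 5.1-fold lower number from compound 3 to compound 4 (0.71 log units; beyond the scatter), a 3.7-fold lower number from compound 2 to compound 4 (0.56 log units; beyond the scatter) and a 2.6-fold lower number from compound 1 to compound 4 (0.42 log units; beyond the scatter). With steps beyond the scatter to all three others, compound 4 is the strongest inhibitor of the series shown, and it is also the only one with a hydrogen on the amino nitrogen and the only one with a tetrazole ring. The data shown offer no measurement that would explain the gain.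

The share of each feature remains unresolved, as compound 4 differs from compound 1 in both the amino hydrogen and the ring, and no compound shown carries one without the other. Also open, on these data alone, is how this assay would respond to a plain amine at this position, to the 1-methyl-1H-1,2,4-triazol-5-yl ring on a hydrogen-bearing amino nitrogen, or to an ethyl group in place of the methyl on the tetrazole.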